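Swapping the fluorinated benzamide for a dichlorinated one

This account rests on a few compounds, and the source may have more. Where it says the series, first, only, none or still open, it means among the compounds named here.

Three analogues sharing one core have been examined in a functional assay on HEK293 cells for agonist activity at probable G-protein coupled receptor 27 (Homo sapiens), read by a luciferase reporter and beta-arrestin recruitment, with a stated time of 10 min; a higher number here means that more compound is needed for the effect, a lower number that less compound is needed. Compound 1 `O=C(Nc1ccc(S(=O)(=O)Nc2ccccc2)cc1)c1ccc(Cl)cc1Br` gives 1020 nM, compound 2 `O=C(Nc1ccc(S(=O)(=O)Nc2ccccc2)cc1)c1ccc(Cl)nc1F` gives 2290 nM, and compound 3 `O=C(Nc1ccc(S(=O)(=O)Nc2ccccc2)cc1)c1cc(F)c(Cl)cc1F` gives 141 nM, the lowest of the three numbers. The next compound, compound 4 `O=C(Nc1ccc(S(=O)(=O)Nc2ccccc2)cc1)c1ccc(Cl)cc1Cl`, differs from compound 3 by 2,4-dichlorophenyl in place of 4-chloro-2,5-difluorophenyl on a carbonyl carbon. Compound 1 is the nearest measured relative of compound 4, and the step of a 7.2-fold lower number from compound 1 to compound 3 (0.86 log units; beyond the scatter) shows how far compound 3 moved away from it; the step of a 16-fold lower number from compound 2 to compound 3 (1.21 log units; beyond the scatter) points the same way. Compound 4 is therefore expected to sit between compound 1 and compound 3, with the step of a 3.9-fold higher number from compound 3 to compound 4 (0.59 log units; beyond the scatter) expected. For compound 4 the estimate in this assay is 550 nM, with a range from 180 nM to 1700 nM.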

Compound 4, half-maximal effective concentration: 457 nM
Beside the measured number, compound 4's estimate is 1.2-fold (0.08 log units) above it, within the range that was stated.
By their numbers in this assay, from the lowest: compound 3; then compound 4; then compound 1; then compound 2.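

Compound 1 and compound 4 differ only by one halogen, and chloro in place of bromo on an aromatic carbon lowers the number modestly (a 2.2-fold lower number from compound 1 to compound 4 (0.35 log units; beyond the scatter)), a single-atom effect that the earlier multi-site ring swaps could not isolate. The 2,4-dichlorophenyl group falls short of the 4-chloro-2,5-difluorophenyl group (a 3.2-fold higher number from compound 3 to compound 4 (0.51 log units; beyond the scatter)) but still surpasses the 6-chloro-2-fluoropyridin-3-yl group (a 5.0-fold lower number from compound 2 to compound 4 (0.70 log units; beyond the scatter)). On these data alone, whether a methyl or a methoxy group in place of that same halogen would lower the number further stays open. No available evidence accounts for these differences.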